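Hydroxyanilino analogues against a colon carcinoma line

The source may report more compounds than this note shows. Statements on the series, on what has been measured and on what is new or still open speak of the compounds shown alone.

Measured so far:
compound 1: `COc1ccc(Nc2nc(-c3cccc(F)c3)nc3ccc(F)cc23)cc1`, 46800 nM
compound 2: `Oc1ccc(Nc2nc(-c3cccc(F)c3)nc3ccc(F)cc23)cc1`, > 50000 nM

The two measured compounds share one core and differ only at the oxygen on the aniline ring. In a functional assay on COLO 205 cells (Homo sapiens) for cytotoxicity, read by MTT assay, with a stated time of 48 h (on this read-out lower numbers stand for stronger inhibition and higher numbers for weaker inhibition), compound 1 gives 46800 nM. Compound 2 gives only a limit in this assay, > 50000 nM, so its true value is not known. The step from methyl to hydrogen, an at least 1.0-fold higher number from compound 1 to compound 2 (0.02 log units; that floor lies within the scatter), therefore sets only a floor and carries no information on direction; the relevant limit is the limit of > 50000 nM in this assay, at which 1 of the 2 values shown sits.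

Compound 3, `Oc1cccc(Nc2nc(-c3cccc(F)c3)nc3ccc(F)cc23)c1`, is not yet measured. Its change against compound 2 is 3-hydroxyphenyl in place of 4-hydroxyphenyl on a nitrogen on an aromatic ring. Among the compounds with values here, no measured step concerns a shift of a group around the aniline ring, so nothing here bears directly on this change; both measured compounds sit at the weak end of the range of this assay. Compound 3 is therefore expected to stay near that end, with an expected step of a number no higher from compound 2 to compound 3 (the limit leaves the size open) and no direction beyond the scatter. The estimate for compound 3 is 50000 nM, with an expected range from 20000 nM to 120000 nM, and a considerable chance that only a limit is reported.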

Compound 3, half-maximal inhibitory concentration: > 50000 nM
Compound 3 gave a limit, no number; the forecaster's own chance of this, stated with the estimate: 60%; the middle value sits exactly at the limit.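

With 3-hydroxyphenyl in place of 4-hydroxyphenyl on the nitrogen, this assay still yields no number for compound 3, whose > 50000 nM is a limit. Neither of the two hydroxyphenyl compounds therefore gives a readable value, and the step between them cannot be read: the limit of > 50000 nM in this assay, at which 2 of the 3 values shown sit. The comparison with the 4-methoxyphenyl compound gives an at least 1.0-fold higher number from compound 1 to compound 3 (0.02 log units; that floor lies within the scatter), so this change, like the earlier one at the oxygen, sets no direction.

The compounds shown leave open whether the placement of the hydroxyl on this ring matters at all, since any difference between the two hydroxyphenyl compounds would lie beyond the limit of the read-out. They also leave open whether a different group on this ring, such as an amine or a carboxylic acid, would bring the series to a measurable value clearly stronger than that of compound 1.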